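This account rests on a few compounds, and the source may have more. Where it says the series, first, only, none or still open, it means among the compounds named here.

Compound 1, `CCC[C@@H](CCO)Nc1nc(N)nc(C)c1Cc1ccc(CN(C)CC(N)=O)cc1OC`, in an assay on HEK293 cells for agonist activity at Toll-like receptor 8 (Homo sapiens) (on this read-out higher numbers stand for an effect only at larger amounts of compound and lower numbers for an effect already at smaller amounts), gives > 10000 nM, which is a limit of the assay and not a number.
Compound 2, `CCC[C@@H](CCO)Nc1nc(N)nc(C)c1Cc1ccc(CNC)cc1OC`, gives 6460 nM.
Compound 3, `CCC[C@@H](CO)Nc1nc(N)nc(C)c1Cc1ccc(CNC)cc1OC`, gives 2140 nM.

Among these three, compound 3 stands with the lowest number of the two that are numbers; compound 2 sits a 3.0-fold lower number from compound 2 to compound 3 (0.48 log units; beyond the scatter), and compound 1 is known only through (the limit of > 10000 nM in this assay, at which 1 of the 3 values shown sits). The step from compound 1 to compound 2, an at least 1.5-fold lower number from compound 1 to compound 2 (0.18 log units; that floor lies within the scatter), is the other change seen, and it also sits on the amine nitrogen of the side chain.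

Compound 4, `CCC[C@@H](CO)Nc1nc(N)nc(C)c1Cc1ccc(CNC2CN(C)C2)cc1OC`, differs from compound 3 by one change: 1-methylazetidin-3-yl in place of methyl on an amine nitrogen. Within the data shown here, no measured step replaces the methyl on that nitrogen by a ring, so neither earlier step speaks directly to it. Among the measured compounds shown here, the only change seen at this nitrogen, an at least 1.5-fold lower number from compound 1 to compound 2 (0.18 log units; that floor lies within the scatter), was small, and the shared core with the hydroxy chain of compound 3 is kept. The step in this assay is therefore expected to be modest, perhaps a little toward a lower number, with the possibility that it stays within the scatter.

Compound 4 is accordingly estimated to give 1500 nM, with a range from 500 nM to 5000 nM, which would be a step of a 1.4-fold lower number from compound 3 to compound 4 (0.15 log units; within the scatter).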

Compound 4, half-maximal effective concentration: 6170 nM
Beside the measured number, compound 4's estimate is 4.1-fold (0.61 log units) below it; measured number above the stated range.
By their numbers in this assay, from the lowest: compound 3; then compounds 4 and 2 (each within the scatter of the next). At a limit, above all of these: compound 1.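

In this assay, among these compounds, putting 1-methylazetidin-3-yl in place of methyl on the amine nitrogen gives a 2.9-fold higher number from compound 3 to compound 4 (0.46 log units; beyond the scatter), the first change at this nitrogen whose size lies beyond the scatter. The earlier step at the same nitrogen, an at least 1.5-fold lower number from compound 1 to compound 2 (0.18 log units; that floor lies within the scatter), rests on a limit of the assay and could not show that this position responds to its substituent, whereas the new step shows that it does: a group of five heavy atoms with a four-membered ring, in place of a single carbon, goes with the higher number. Nothing among the values shown gives a cause for this step.

The compounds shown leave open whether the step goes with the ring itself or with its nitrogen, as a cyclobutyl group, 1-methylazetidin-3-yl without its methyl, or a longer chain on the same nitrogen would tell. They also leave open whether 1-methylazetidin-3-yl would have the same effect with the longer hydroxy chain of compound 2, and whether a plain hydrogen on this amine nitrogen would move the number in either direction.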